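A dimethylphenyl in place of fluorophenyl on the ring nitrogen

The source may report more compounds than this note shows. Statements on the series, on what has been measured and on what is new or still open speak of the compounds shown alone.

Compound 3 `Cc1cc(=O)oc2cc(OCc3cn(-c4cccc(F)c4)nn3)ccc12` is one of three close relatives tested in an ADME assay on Huh-7 cells (Homo sapiens) for cytotoxicity, read by MTT assay, with a stated time of 72 h; a higher number here means that more compound is tolerated, a lower number that less compound is tolerated. In this assay compound 3 reaches only a limit, > 100 ug/mL. Compound 1 `Cc1cc(=O)oc2cc(OCc3cn(-c4ccccc4Cl)nn3)ccc12` likewise reaches only a limit in this assay, > 100 ug/mL. Compound 2 `Cc1cc(=O)oc2cc(OCc3cn(-c4ccccc4F)nn3)ccc12` also reaches only a limit in this assay, > 100 ug/mL. The steps among them, a step that the two limits leave unreadable from compound 1 to compound 2, a step that the two limits leave unreadable from compound 1 to compound 3 and a step that the two limits leave unreadable from compound 2 to compound 3, cannot be sized because all three numbers sit at the limit of > 100 ug/mL in this assay, at which 3 of the 3 values shown sit. Compound 3 therefore stands where its two relatives stand, at the limit, and nothing separates the three.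

Compound 4 `Cc1cc(C)cc(-n2cc(COc3ccc4c(C)cc(=O)oc4c3)nn2)c1` differs from compound 3 by 3,5-dimethylphenyl in place of 3-fluorophenyl on an aromatic nitrogen. All three measured steps bear on this change in that each exchanges the group on that aromatic nitrogen, and each left the readout in this assay at the limit; none of them gives a readable size in either direction. The step is therefore expected to be none beyond the scatter, a step that the limit leaves unreadable from compound 3 to compound 4, and the readout is expected to remain a limit. Compound 4 is estimated at 150 ug/mL in this assay, ranging from 80 ug/mL to 300 ug/mL.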

Compound 4, half-maximal cytotoxic concentration: > 100 ug/mL
Compound 4 ended at the assay's limit; the forecaster's own chance of this, stated with the estimate: 85%; the middle value does not contradict the limit.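

In this assay compound 4 gives > 100 ug/mL, which is a limit of the assay and not a number. No step from compound 1, compound 2 or compound 3 to compound 4 can be read, because all four values sit at the same limit: the limit of > 100 ug/mL in this assay, at which 4 of the 4 values shown sit.

The compounds shown leave open whether exchanging the group on the aromatic nitrogen changes the readout at all.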